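Swapping a lactam for an aryl amine on a soluble core

The source may hold more compounds than are shown below. What is called first, only, known or untested is meant among the compounds shown, and "the series" means these compounds.

Measured so far:
- compound 1 `C[C@@H]1CC(=O)N(c2cnc(NCc3c(F)ccc4c3CCO4)n3cnnc23)C1`: 130000 nM
- compound 2 `Cc1nc(CO)ccc1-c1cnc(NCc2c(F)ccc3c2CCO3)c2cn[nH]c(=O)c12`: 3000 nM
- compound 3 `O=C1CCCN1c1cnc(NCc2c(F)ccc3c2CCO3)c2cn[nH]c(=O)c12`: a limit, < 2000 nM

Compound 1 stands highest of the numbers known in a physicochemical assay for solubility, read by LC-MS, in phosphate buffer, with a stated time of 24 h, at pH 7.4; on this read-out higher numbers stand for higher solubility and lower numbers for lower solubility; the nearest number belongs to compound 2, which lies well beneath it. Compound 3 gives only a limit of the assay in this assay, so it supplies no number of its own. Among the compounds with values here, the one measured step that involves a lactam is an at least 1.5-fold lower number from compound 2 to compound 3 (0.17 log units; that floor lies within the scatter), and since its floor lies within the scatter it shows no clear direction for exchanging an aromatic group against a lactam, and it sits on a different core from compound 1 in any case.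

Compound 4 `CN(c1cccnc1)c1cnc(NCc2c(F)ccc3c2CCO3)n2cnnc12` is compound 1 with a single exchange: methyl(pyridin-3-yl)amino in place of 4-methyl-2-oxopyrrolidin-1-yl on an aromatic carbon. Within the data shown here, no measured pair shows this particular exchange, and the only related step gives no size beyond the scatter. The expectation is therefore a modest decrease for compound 4, with a wide band around it, as a 3.3-fold lower number from compound 1 to compound 4 (0.51 log units; beyond the scatter).

Compound 4 is estimated to give about 40000 nM in this assay, within a range from 10000 nM to 130000 nM.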

Compound 4, solubility: 47000 nM
Compound 4: the middle estimate sits 1.2-fold (0.07 log units) below what was measured; the range from low to high includes it.
By their numbers in this assay, from the lowest: compound 2; then compound 4; then compound 1. At a limit, below all of these: compound 3.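

In this assay, putting methyl(pyridin-3-yl)amino in place of 4-methyl-2-oxopyrrolidin-1-yl on the aromatic carbon of the shared core gives a 2.8-fold lower number from compound 1 to compound 4 (0.44 log units; beyond the scatter). This is a step with a clear direction at this position on this core, which the earlier step between a lactam and an aromatic group could not supply, since it sat on another core and its floor lay within the scatter. The exchange changes several things at once: a five-membered non-aromatic ring with a defined stereocentre and a double bond outside aromatic rings leaves, and a six-membered aromatic ring with a ring nitrogen enters, and nothing shown here accounts for the size of the step.

The compounds shown leave open which of these features carries the change, since a single pair cannot separate them. A plain dimethylamino group, a phenyl ring in place of the pyridine ring, or a morpholine on the same carbon would each test one part of the exchange and show whether the number follows the aromatic ring or the loss of the lactam.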